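A Pyrazole Acid Replaces the Fluorophenyl Ether

This account rests on a few compounds, and the source may have more. Where it says the series, first, only, none or still open, it means among the compounds named here.

Compound 2 `COc1ncc(-c2ccc3ncnc(Nc4ccc(OCCO)c(F)c4)c3c2)cc1NS(=O)(=O)c1ccc(F)cc1F` gives 9160 nM in a functional assay on HCT-116 cells (Homo sapiens) for antiproliferative activity, read by sulforhodamine B assay, with a stated time of 72 h (a lower number here means a stronger inhibitor, a higher number a weaker inhibitor), the highest of the three numbers measured. Compound 1 `COc1ncc(-c2ccc3ncnc(Nc4ccc(OCCO)cc4)c3c2)cc1NS(C)(=O)=O` gives 4860 nM, within the scatter of compound 2, while compound 3 `COc1ncc(-c2ccc3ncnc(Nc4cnn(CCCO)c4)c3c2)cc1NS(C)(=O)=O` gives 1420 nM, beyond it. Compound 4 `COc1ncc(-c2ccc3ncnc(Nc4cnn(CC(=O)O)c4)c3c2)cc1NS(=O)(=O)c1ccc(F)cc1F` differs from compound 2 by 1-(carboxymethyl)-1H-pyrazol-4-yl in place of 3-fluoro-4-(2-hydroxyethoxy)phenyl on a nitrogen on an aromatic ring. Going by the values given here, the one measured step that bears on this is a 3.4-fold lower number from compound 1 to compound 3 (0.53 log units; beyond the scatter), which also exchanges the phenyl ether for a pyrazolyl group, although there the ring carried 1-(3-hydroxypropyl) and here it carries carboxymethyl, an exchange no measured pair covers. A modest step toward a lower number is therefore expected, a 1.8-fold lower number from compound 2 to compound 4 (0.26 log units; within the scatter), with wide uncertainty. Compound 4 is estimated at 5000 nM, in a range from 1200 nM to 20000 nM.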

Compound 4, half-maximal inhibitory concentration: 1540 nM
Beside the measured number, compound 4's estimate is 3.2-fold (0.51 log units) above it; low and high end bracket the measured number.
By their numbers in this assay, from the lowest: compounds 3 and 4 (each within the scatter of the next); then compounds 1 and 2 (each within the scatter of the next).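

In this assay, the exchange at this nitrogen gives a 5.9-fold lower number from compound 2 to compound 4 (0.77 log units; beyond the scatter), so the step toward a lower number seen with 1-(3-hydroxypropyl)-1H-pyrazol-4-yl also appears with 1-(carboxymethyl)-1H-pyrazol-4-yl, on a core carrying a different sulfonamide. Both listed exchanges of a substituted phenyl for a substituted pyrazolyl point the same way, and neither goes against the other. Nothing shown accounts for this step. From the compounds shown here alone, how much of it belongs to the ring and how much to the carboxymethyl chain remains open, as does whether a methyl ester or a primary amide would behave like the carboxylic acid.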